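Extending the Ether Chain: From Compound 2 to Compound 4

The compounds below may be only part of what the source reports. "The series", "measured", "known", "first", "only" and "open" are said of these compounds alone.

compound 1 `CC(C)COc1ccc2c(Cl)ccnc2c1` — 2100 nM
compound 2 `CCOc1ccc2c(Cl)ccnc2c1` — 3340 nM
compound 3 `CC(C)Oc1ccc2c(Cl)ccnc2c1` — 2310 nM

In a functional assay on NCI-H1650 cells (Homo sapiens) for cytotoxicity, read by MTT assay, with a stated time of 48 h (a lower number here means a stronger inhibitor, a higher number a weaker inhibitor), the three measured compounds sit close together. Compound 2 shows the highest of the three numbers, yet both of its gaps, a 1.4-fold lower number from compound 2 to compound 3 (0.16 log units; within the scatter) and, read the other way, a 1.6-fold higher number from compound 1 to compound 2 (0.20 log units; within the scatter), are within the scatter, so no real order can be drawn. Compound 4 `Clc1ccnc2cc(OCCc3ccccc3)ccc12` differs from compound 2 by phenyl in place of hydrogen on a saturated chain carbon, two bonds along the chain from an oxygen on an aromatic ring. The measured steps concern only small alkyl changes on the oxygen, and none adds a ring, so they bear loosely on this change; since all of them, a 1.1-fold higher number from compound 1 to compound 3 (0.04 log units; within the scatter) included, stayed within the scatter, only a modest step is expected, a 1.3-fold lower number from compound 2 to compound 4 (0.13 log units; within the scatter), with uncertain direction. Compound 4 is therefore estimated at 2500 nM, between 900 nM and 7000 nM.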

Compound 4, half-maximal inhibitory concentration: 2300 nM
Estimate against measurement, compound 4: 1.1-fold (0.04 log units) above, and the stated range covers the measured number.
By their numbers in this assay, from the lowest: compounds 1, 4, 3 and 2 (each within the scatter of the next).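

Earlier compounds in this assay varied only small alkyl groups on the oxygen, whereas compound 4 carries a phenyl ring on the chain, and even this larger addition gives only a step within the scatter (a 1.5-fold lower number from compound 2 to compound 4 (0.16 log units; within the scatter)). This place on the chain therefore accepts a six-membered aromatic ring of carbon only, with no difference that can be told from repeat-measurement noise. No evidence is available to explain this result. Going by these compounds, it remains open whether an amine, a carboxylic acid or a longer chain at this place would also leave the number unmoved.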